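Swapping the basic side chain for a methoxyamide

The compounds below may be only part of what the source reports. "The series", "measured", "known", "first", "only" and "open" are said of these compounds alone.

Compound 1, `CCN1CCN(C[C@H]2CN(c3ccc(-n4cc(-c5ccccn5)cn4)c(F)c3)C(=O)O2)CC1`, is tested in an ADME assay on HEK293-A cells (Homo sapiens) for cytotoxicity, read by MTT assay, with a stated time of 48 h (a lower number here means a stronger inhibitor, a higher number a weaker inhibitor), where compound 1 gives 99 ug/mL. Among the numbers shown, compound 1 stands lowest; its nearest neighbour is compound 3, `CCC(=O)NC[C@H]1CN(c2ccc(-n3cc(-c4ccccn4)cn3)c(F)c2)C(=O)O1`, which in this assay gives 389 ug/mL, a step of a 3.9-fold higher number from compound 1 to compound 3 (0.59 log units; beyond the scatter). Compound 2, `O=C1CCC(=O)N1C[C@H]1CN(c2ccc(-n3cc(-c4ccccn4)cn3)c(F)c2)C(=O)O1`, reaches only a limit of this assay, > 400 ug/mL. That reading for compound 2 is the one described by the limit of > 400 ug/mL in this assay, at which 1 of the 3 values shown sits. The step of an at least 4.0-fold higher number from compound 1 to compound 2 (0.60 log units; beyond the scatter) is thus a floor on the change, and the step of an at least 1.0-fold lower number from compound 2 to compound 3 (0.01 log units; that floor lies within the scatter) shows that the two neutral groups in compound 2 and compound 3 cannot be told apart.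

Compound 4, `CONC(=O)[C@H]1CN(c2ccc(-n3cc(-c4ccccn4)cn3)c(F)c2)C(=O)O1`, has not yet been measured in this assay. It differs from compound 1 in that (methoxycarbamoyl in place of (4-ethylpiperazin-1-yl)methyl on a saturated ring carbon). Both measured steps that remove the 4-ethylpiperazin-1-yl group raised the number by a modest amount, and the group entering compound 4 likewise carries no net charge, so a shift of similar size and direction is expected for compound 4, namely a 3.3-fold higher number from compound 1 to compound 4 (0.52 log units; beyond the scatter). Compound 4 is therefore estimated to give about 330 ug/mL in this assay, with an expected range from 150 ug/mL to 450 ug/mL.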

Compound 4, half-maximal inhibitory concentration: > 400 ug/mL
Compound 4: no number, only a limit; the forecaster's own chance of this, stated with the estimate: 40%; middle value at least 1.2-fold (0.08 log units) from the limit.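

The replacement here goes further than the earlier ones, which changed only what sits on the saturated chain carbon. Methoxycarbamoyl replaces the whole (4-ethylpiperazin-1-yl)methyl group on the saturated ring carbon, and the result is an at least 4.0-fold higher number from compound 1 to compound 4 (0.60 log units; beyond the scatter) in this assay. Compound 3 and compound 4 cannot be told apart, as the floor of an at least 1.0-fold higher number from compound 3 to compound 4 (0.01 log units; that floor lies within the scatter) shows, so removing the chain carbon and swapping propanoylamino for methoxycarbamoyl brings no readable change, and the step between compound 2 and compound 4 cannot be read. All three compounds without the 4-ethylpiperazin-1-yl group now lie beyond the scatter from compound 1, none goes against this, and compound 4 stands at a limit, as compound 2 does: the limit of > 400 ug/mL in this assay, at which 2 of the 4 values shown sit.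

The compounds shown leave open whether the lower number of compound 1 goes with the whole 4-ethylpiperazin-1-yl group or with an amine alone, which a morpholine ring or a primary amine on the same chain carbon would help to separate. They also leave open what a carboxylic acid on the saturated ring carbon would give in this assay.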